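Working notes: bromo to fluoro exchange toward compound 3

The source may report more compounds than this note shows. Statements on the series, on what has been measured and on what is new or still open speak of the compounds shown alone.

Measured so far:
- compound 1 `COc1ccc(/C=N/NC(=O)CSc2nnc(-c3ccncc3)n2-c2ccccc2)cc1`: 19200 nM
- compound 2 `O=C(CSc1nnc(-c2ccncc2)n1-c1ccccc1)N/N=C/c1ccc(Br)cc1`: 4500 nM

In a functional assay on HCT-116 cells (Homo sapiens) for inhibition, read by MTT assay, with a stated time of 48 h (a higher number here means a weaker inhibitor, a lower number a stronger inhibitor), compound 1 gives 19200 nM, while compound 2 gives 4500 nM. Among the measured compounds shown here, the one measured step, a 4.3-fold lower number from compound 1 to compound 2 (0.63 log units; beyond the scatter), is bromo in place of methoxy on an aromatic carbon. For the measured compounds named here, compound 2 therefore stands lowest of the two numbers, with compound 1 as its only neighbour.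

Compound 3 `O=C(CSc1nnc(-c2ccncc2)n1-c1ccccc1)N/N=C/c1ccc(F)cc1` differs from compound 2 by fluoro in place of bromo on an aromatic carbon. Going by the values given here, no measured step exchanges one halogen for another; the bromo-for-methoxy step is the only guide and shows that a change at this aromatic carbon can move this assay beyond the scatter. A move back toward a higher number, smaller than that step, is expected: a 1.8-fold higher number from compound 2 to compound 3 (0.25 log units; within the scatter) is the estimated step. Compound 3 is thus expected near 8000 nM, in a range from 3000 nM to 22000 nM.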

Compound 3, half-maximal inhibitory concentration: 7040 nM
Beside the measured number, compound 3's estimate is 1.1-fold (0.06 log units) above it, and the stated range covers the measured number.
By their numbers in this assay, from the lowest: compounds 2 and 3 (each within the scatter of the next); then compound 1.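

In this assay the change from 4-bromophenyl to 4-fluorophenyl gives a 1.6-fold higher number from compound 2 to compound 3 (0.19 log units; within the scatter) and so does not separate the two halogens at this aromatic carbon. The lower number relative to methoxy is therefore not confined to bromo, since fluoro in place of methoxy also gives a 2.7-fold lower number from compound 1 to compound 3 (0.44 log units; beyond the scatter) beyond the scatter. The series offers no evidence on why these groups read as they do.

Going by these compounds, how an amine or a carboxylic acid at this carbon would compare with methoxy and the two halogens remains open. All three groups sit at the same place, para to a large group, on an otherwise unchanged core, so their effect elsewhere on the ring or on another core is also unknown.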